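The source may report more compounds than this note shows. Statements on the series, on what has been measured and on what is new or still open speak of the compounds shown alone.

Three compounds share one core and differ only at one end of it. Compound 1 `CCOc1cnc(N2CCC([C@H]3C[C@H]3COCc3ccc(S(C)(=O)=O)c(F)c3)CC2)nc1` carries an ethoxy group on an aromatic carbon and in a functional assay on isolated protein for agonist activity at Glucose-dependent insulinotropic receptor (Mus musculus), read by cAMP accumulation (a lower number here means that less compound is needed, a higher number that more compound is needed for the effect), compound 1 gives 2.3 nM. Compound 2 `COCc1cnc(N2CCC([C@H]3C[C@H]3COCc3ccc(S(C)(=O)=O)c(F)c3)CC2)nc1` carries a methoxymethyl group in that place and in this assay compound 2 gives 5.2 nM. Compound 3 `CCc1cnc(N2CCC([C@H]3C[C@H]3COCc3ccc(S(C)(=O)=O)c(F)c3)CC2)nc1` carries an ethyl group there and in this assay compound 3 gives 5.5 nM. Among these three numbers compound 2 stands second highest: the step of a 2.3-fold higher number from compound 1 to compound 2 (0.35 log units; beyond the scatter) is modest, the step of a 2.4-fold higher number from compound 1 to compound 3 (0.38 log units; beyond the scatter) is of similar size, and the step of a 1.1-fold higher number from compound 2 to compound 3 (0.02 log units; within the scatter) is within the scatter, so compound 2 and compound 3 cannot be told apart.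

Compound 4 `COCc1cnc(N2CCC([C@H]3C[C@H]3COCc3ccc(-n4cnnn4)c(F)c3)CC2)nc1` differs from compound 2 at the opposite end of the core: 1H-tetrazol-1-yl in place of methylsulfonyl on an aromatic carbon. None of the three measured steps touches this end; each of them concerns the ethoxy, methoxymethyl or ethyl group on the other ring. The data therefore give no direct guide, and the expectation rests only on the fact that exchanges elsewhere moved the numbers modestly. Compound 4 is expected to give 8 nM, within 2 nM to 40 nM, which means an estimated step of a 1.5-fold higher number from compound 2 to compound 4 (0.19 log units; within the scatter).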

Compound 4, half-maximal effective concentration: 3.8 nM
Estimate against measurement, compound 4: 2.1-fold (0.32 log units) above, and the stated range covers the measured number.
By their numbers in this assay, from the lowest: compounds 1, 4, 2 and 3 (each within the scatter of the next, the first and the last beyond it).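

Among these compounds, at this end of the core, which none of the earlier steps touched, replacing methylsulfonyl with 1H-tetrazol-1-yl in this assay gives a 1.4-fold lower number from compound 2 to compound 4 (0.14 log units; within the scatter), so the two compounds cannot be told apart. The two groups are quite different in build: methylsulfonyl has 4 heavy atoms and no ring, whereas 1H-tetrazol-1-yl has 5 heavy atoms in one five-membered aromatic ring with 4 hetero atoms, yet this place on the aromatic carbon, ortho to a fluoro group and para to a large group, accepts either without a readable shift in the number. No measurement shown here accounts for this match.

The compounds shown leave open whether the same exchange would also give an indistinguishable number with the ethoxy group of compound 1 or the ethyl group of compound 3 at the other end of the core. They also leave open how far this place accepts other groups, for example a carboxylic acid, an amine or a nitrile, since methylsulfonyl and 1H-tetrazol-1-yl are the only two seen here.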